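Benzyl ether on the unsaturated core: expected binding

The compounds below may be only part of what the source reports. "The series", "measured", "known", "first", "only" and "open" are said of these compounds alone.

Measured so far:
compound 1 `CN1CC[C@@H]2CC[C@H](OCc3ccccc3)C[C@@H]21`, 100000 nM
compound 2 `CO[C@H]1CC=C2CCN(C)[C@H]2C1`, 100000 nM
compound 3 `CCO[C@H]1CC=C2CCN(C)[C@H]2C1`, > 300000 nM

All values come from an assay on HEK293 cells for displacement of a labelled ligand from Neuronal acetylcholine receptor; alpha3/beta4 (Rattus norvegicus), with a stated time of 4 h; a higher number here means a weaker inhibitor, a lower number a stronger inhibitor. Among the measured compounds shown here, compound 3 sits at > 300000 nM, a limit of the assay and not a number; it is the one value shown at that limit (the limit of > 300000 nM in this assay, at which 1 of the 3 values shown sits). Compound 4 `CN1CCC2=CC[C@H](OCc3ccccc3)C[C@@H]21` is not yet measured. It differs from compound 3 by phenyl in place of methyl on a saturated chain carbon bound to an oxygen on a saturated carbon. For the measured compounds named here, the only step measured in the same position is an at least 3.0-fold higher number from compound 2 to compound 3 (0.47 log units; beyond the scatter). Compound 1 carries the same benzyl ether on a saturated core and gives 100000 nM, within the same weak range as compound 2. Compound 4 is therefore expected near this weak range, at 150000 nM, between 50000 nM and 500000 nM. The expected step is an at least 2.0-fold lower number from compound 3 to compound 4 (0.30 log units; that floor lies within the scatter), with a fair chance that only a limit is reported.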

Compound 4, inhibition constant: 300000 nM
Estimate against measurement, compound 4: 2.0-fold (0.30 log units) below; the measured number falls inside the stated range.
By their numbers in this assay, from the lowest: compounds 1 and 2 (each within the scatter of the next); then compound 4.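

In this assay, replacing the methyl ether with the benzyl ether gives a 3.0-fold higher number from compound 2 to compound 4 (0.48 log units; beyond the scatter). On the shared core, an aromatic ring at this position therefore brings no gain over the smaller methyl ether of compound 2. Compound 3 gives only a limit of the assay: the limit of > 300000 nM in this assay, at which 1 of the 4 values shown sits. The step that follows is a number no higher from compound 3 to compound 4 (the limit leaves the size open), so its size cannot be read.

As far as these compounds go, whether an amine or a carboxylic acid on this ether, or a longer chain carrying the phenyl, would lower the number stays open.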